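This account rests on a few compounds, and the source may have more. Where it says the series, first, only, none or still open, it means among the compounds named here.

Working notes on the series. Among the measured compounds shown here, compound 1 `O/N=C(/Nc1cccc(F)c1)c1ccc2occc2c1` gives 32700 nM in an assay on isolated protein for inhibition of Indoleamine 2,3-dioxygenase 1 (Homo sapiens), read by spectrophotometry (a higher number here means a weaker inhibitor, a lower number a stronger inhibitor), the highest of the two numbers measured so far; its nearest neighbour is compound 2 `O/N=C(/Nc1cccc(Br)c1)c1ccc2occc2c1`, which in this assay gives 440 nM. For the measured compounds named here, the only measured step, a 74-fold lower number from compound 1 to compound 2 (1.87 log units; beyond the scatter), is large and concerns bromo in place of fluoro on an aromatic carbon. Compound 3 `O/N=C(/Nc1cccc(F)c1)c1ccc2oc(COCC3CC3)cc2c1` differs from compound 1 at a different place: (cyclopropylmethoxy)methyl in place of hydrogen on an aromatic carbon, on an aromatic carbon of the five-membered aromatic ring of the shared core, next to the ring oxygen. Going by the values given here, no measured step in this set touches that position, so the halogen step gives no direct guide to the size or direction of the change. With nothing to anchor it, compound 3 is expected to land around 15000 nM, within 3000 nM to 60000 nM. This corresponds to an expected step of a 2.2-fold lower number from compound 1 to compound 3 (0.34 log units; beyond the scatter), leaning toward a lower number but not confidently beyond the scatter.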

Compound 3, half-maximal inhibitory concentration: 2200 nM
Compound 3: middle estimate off by 6.8-fold (0.83 log units), on the high side; the whole stated range lies above it.
By their numbers in this assay, from the lowest: compound 2; then compound 3; then compound 1.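

In this assay the aromatic carbon next to the ring oxygen, on the five-membered aromatic ring of the shared core, tolerates far more than hydrogen: (cyclopropylmethoxy)methyl there gives a 15-fold lower number from compound 1 to compound 3 (1.17 log units; beyond the scatter) with the fluoro group unchanged. This position is therefore a second place in the series where a single change moves the number well beyond the scatter, and here a group is added rather than one halogen exchanged for another. Nothing available bears on the cause of this step, which stands as an observation only.

From the compounds shown here alone, it remains open whether the cyclopropyl ring, the chain oxygen or the chain alone carries the step, and whether a plain methyl, an aminomethyl or a carboxylic acid at this carbon would move the number the same way. Also open, going by these compounds, is whether this step and the bromo step would add up in a single compound.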